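Thiophene-fused ester series: second methoxy on the aryl ring

The source may hold more compounds than are shown below. What is called first, only, known or untested is meant among the compounds shown, and "the series" means these compounds.

Among the compounds with values here, compound 1 `CCOC(=O)[C@@H]1CC(=O)c2sccc2[C@H]1c1ccc(OC)cc1` is one of two compounds measured in a physicochemical assay, read by spectrophotometry, with a stated time of 20 min, tested at 40 ug/mL; on this read-out higher numbers stand for a stronger effect at the one concentration tested and lower numbers for a weaker effect. In this assay compound 1 gives 16.7%, and compound 2 `CCOC(=O)[C@@H]1CC(=O)c2sccc2[C@H]1c1ccc(OCC)cc1` gives 18.5%; the two are separated by a number 1.8 percentage points higher from compound 1 to compound 2 (within the scatter), so neither can be set apart from the other. Compound 3 `CCOC(=O)[C@@H]1CC(=O)c2sccc2[C@H]1c1ccc(OC)c(OC)c1` differs from compound 1 by methoxy in place of hydrogen on an aromatic carbon. Within the data shown here, the only measured step, from compound 1 to compound 2, altered the group on the same aromatic ring and stayed within the scatter; no measured step adds a second group to that ring, so it bears on the present change only by analogy. On this basis no movement beyond the scatter is expected, which means an expected step of a number 1.3 percentage points higher from compound 1 to compound 3 (within the scatter). For compound 3 the estimated value in this assay is 18%, with a range from 8% to 30%.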

Compound 3, a percentage reported as activity, at one concentration (the size of the read-out at that concentration, not a potency): 14.8%
Compound 3: the middle estimate sits 3.2 percentage points above what was measured; measured number inside the range.
By their numbers in this assay, from the lowest: compounds 3, 1 and 2 (each within the scatter of the next).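

In this assay, methoxy in place of hydrogen on this aromatic carbon, ortho to a methoxy group and meta to a large group, gives a number 1.9 percentage points lower from compound 1 to compound 3 (within the scatter), so this second group on the ring cannot be set apart from hydrogen. With a number 1.8 percentage points higher from compound 1 to compound 2 (within the scatter), both changes shown on this ring now stay within the scatter, one lengthening the existing group and the other adding a new group at a further ring carbon. Nothing available accounts for this result.

On these data alone, it remains open whether a hydroxyl, an amine or a carboxylic acid at this same aromatic carbon would move the read-out beyond the scatter. Also open, as far as these compounds go, is whether a change away from this ring, such as a carboxylic acid in place of the ethyl ester, would do so.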